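The compounds below may be only part of what the source reports. "The series", "measured", "known", "first", "only" and "open" are said of these compounds alone.

Compound 2 `O=C(Nc1ccc(Oc2ccnc3[nH]ccc23)c(F)c1)c1ccc(-c2ccc(F)cc2)cn1` holds the highest of the two numbers measured in a functional assay on A549 cells (Homo sapiens) for cytotoxicity, read by MTT assay, with a stated time of 72 h (on this read-out higher numbers stand for weaker inhibition and lower numbers for stronger inhibition), giving 6010 nM. For the measured compounds named here, its nearest neighbour, compound 1 `COc1ccc(-c2ccc(C(=O)Nc3ccc(Oc4ccnc5[nH]ccc45)c(F)c3)nc2)cc1`, gives 2240 nM in this assay, and the one measured step between them, a 2.7-fold higher number from compound 1 to compound 2 (0.43 log units; beyond the scatter), is a fluoro in place of methoxy on an aromatic carbon. Compound 3 `O=C(Nc1ccc(Oc2ccnc3[nH]ccc23)c(F)c1)c1ccc(-c2ccc(F)cc2F)cn1` differs from compound 2 by fluoro in place of hydrogen on an aromatic carbon; read one bond further out, this is 4-fluorophenyl to 2,4-difluorophenyl. Going by the values given here, no measured step involves a fluoro in place of hydrogen, so the step from compound 1 to compound 2 is only a distant guide: it shows that changes on this outer ring move the number by a modest amount. For compound 3 the expected step in this assay is therefore a 1.0-fold lower number from compound 2 to compound 3 (0.00 log units; within the scatter), likely within the scatter. Compound 3 is estimated at 6000 nM, within 2500 nM to 14000 nM.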

Compound 3, half-maximal inhibitory concentration: 3100 nM
The estimate for compound 3 lay 1.9-fold (0.29 log units) above the measured number; the range from low to high includes it.
By their numbers in this assay, from the lowest: compounds 1, 3 and 2 (each within the scatter of the next, the first and the last beyond it).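

In this assay, fluoro in place of hydrogen on the aromatic carbon ortho to a large group and meta to a fluoro group gives a step within the scatter (a 1.9-fold lower number from compound 2 to compound 3 (0.29 log units; within the scatter)), so this position accepts the added fluoro with no change that can be read. The wider change, 2,4-difluorophenyl in place of 4-methoxyphenyl, also stays within the scatter (a 1.4-fold higher number from compound 1 to compound 3 (0.14 log units; within the scatter)), which leaves compound 3 separated from neither compound 1 nor compound 2, although those two are separated from each other. Nothing available gives a reason for either step.

Open, on these data alone, is whether a larger group at this position, such as an amine, a carboxylic acid or a longer chain, would move the number beyond the scatter. Also open, as far as these compounds go, is whether the fluoro at this position would give the same step on an outer ring carrying methoxy instead of the 4-fluoro group.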